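Fluoroaryl sulfone series: microsomal clearance working notes

The source may hold more compounds than are shown below. What is called first, only, known or untested is meant among the compounds shown, and "the series" means these compounds.

Measured in an ADME assay on microsomes from liver (Homo sapiens) for metabolic stability, tested at 2.5 uM; on this read-out lower numbers stand for slow clearance and higher numbers for fast clearance:
compound 1 `O=S(=O)(c1ccc(F)cc1)c1cnc2cc(F)ccc2c1-c1ccc(F)cc1` gives 1.34 mL/min
compound 2 `O=S(=O)(c1ccc(F)cc1)c1cnc2cc(F)ccc2c1-c1ccc(Cl)cc1` gives 1.23 mL/min
compound 3 `O=S(=O)(c1ccc(F)cc1)c1cnc2c(F)cccc2c1-c1cccc(F)c1` gives 1.56 mL/min

Compound 1 sits second highest of the three numbers in this assay, with compound 2 its nearest neighbour and compound 3 the furthest; both gaps are within the scatter. Within the data shown here, the one step between measured compounds, a 1.1-fold lower number from compound 1 to compound 2 (0.04 log units; within the scatter), is within the scatter and concerns a different position from the change now in question. Compound 4 `O=S(=O)(c1cccc(F)c1)c1cnc2cc(F)ccc2c1-c1ccc(F)cc1` differs from compound 1 by 3-fluorophenyl in place of 4-fluorophenyl on a sulfonyl sulfur. Among the measured compounds shown here, no measured step bears directly on this change; compound 3 carries a 3-fluorophenyl elsewhere and differs from compound 1 in more than one place, so its value is only noted. The expectation is therefore no step beyond the scatter, a 1.0-fold higher number from compound 1 to compound 4 (0.00 log units; within the scatter). Compound 4 is estimated at 1.35 mL/min, range 0.7 mL/min to 2.7 mL/min.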

Compound 4, intrinsic clearance in a liver preparation (reported as CLH), per the amount of preparation that the assay uses: 0.11 mL/min
The estimate for compound 4 lay 12-fold (1.09 log units) above the measured number; the measured number lies below the stated range.
By their numbers in this assay, from the lowest: compound 4; then compounds 2, 1 and 3 (each within the scatter of the next).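

In this assay, 3-fluorophenyl in place of 4-fluorophenyl on a sulfonyl sulfur gives a 12-fold lower number from compound 1 to compound 4 (1.09 log units; beyond the scatter), so clearance at this position changes beyond the scatter even though the atoms stay the same. Among these compounds, the one earlier step, a 1.1-fold lower number from compound 1 to compound 2 (0.04 log units; within the scatter), concerned another place and showed no such sensitivity. Nothing at hand accounts for the size of this step.

Open, from the compounds shown here alone, is whether the low number is specific to 3-fluorophenyl or also holds for other groups on the sulfonyl sulfur, such as unsubstituted phenyl or a methoxyphenyl. Also open, going by these compounds, is whether it carries over to the core of compound 2 or compound 3.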